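The compounds below may be only part of what the source reports. "The series", "measured", "known", "first", "only" and "open" are said of these compounds alone.

Measured in a functional assay on Jurkat cells (Homo sapiens) for inhibition, read by CCK-8 assay, with a stated time of 48 h; a higher number here means a weaker inhibitor of growth, a lower number a stronger inhibitor of growth:
- Compound 1 `CN1CCN(c2ccc(Nc3ncc(Cl)c(NCc4ccc(F)cc4)n3)nc2)CC1`: > 100000 nM, a limit of the assay, not a number
- Compound 2 `COc1ccc(CNc2nc(Nc3ccc(N4CCN(C)CC4)cn3)ncc2Cl)cc1`: 12900 nM
- Compound 3 `COc1cccc(CNc2nc(Nc3ccc(N4CCN(C)CC4)cn3)ncc2Cl)c1`: 73400 nM

Compound 3 holds the higher of the two true numbers, with a 5.7-fold higher number from compound 2 to compound 3 (0.76 log units; beyond the scatter). Compound 4 `Cc1ccc(Nc2nc(Nc3ccc(N4CCN(C)CC4)cn3)ncc2Cl)cc1` has 4-methylphenyl in place of 3-methoxybenzyl on a nitrogen on an aromatic ring. Among the measured compounds shown here, no measured step makes this exact change, so the guide is indirect. Compound 2 carries its group at the 4-position, like compound 4, and an at least 7.7-fold lower number from compound 1 to compound 2 (0.88 log units; beyond the scatter) also shows how far such swaps can move the number. A modest fall is therefore expected, with much uncertainty. The expected change is a 2.4-fold lower number from compound 3 to compound 4 (0.39 log units; beyond the scatter). For compound 4 the estimate is 30000 nM, with an expected range from 6000 nM to 100000 nM.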

Compound 4, concentration for 50% growth inhibition: 30900 nM
Beside the measured number, compound 4's estimate is 1.0-fold (0.01 log units) below it; the measured number falls inside the stated range.
By their numbers in this assay, from the lowest: compound 2; then compound 4; then compound 3. At a limit, above all of these: compound 1.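

The benzyl chain carbon is not needed for growth inhibition in this assay, since 4-methylphenyl on this nitrogen still gives a true number. Its place depends on which benzyl group leaves: it is stronger than 3-methoxybenzyl (a 2.4-fold lower number from compound 3 to compound 4 (0.38 log units; beyond the scatter)) but weaker than 4-methoxybenzyl (a 2.4-fold higher number from compound 2 to compound 4 (0.38 log units; beyond the scatter)). The step that starts from a limit of the assay gives only a floor (an at least 3.2-fold lower number from compound 1 to compound 4 (0.51 log units; beyond the scatter)). Still open, going by these compounds, is how 4-methoxyphenyl on this nitrogen would compare with 4-methoxybenzyl, and how a longer chain such as 2-phenylethyl would fare.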